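The source may hold more compounds than are shown below. What is called first, only, known or untested is meant among the compounds shown, and "the series" means these compounds.

In an assay on MDA-MB-231 cells for binding affinity to C-X-C chemokine receptor type 4 (Homo sapiens), read by fluorescence and microscopy, with stated times of 10 min and 30 min (a higher number here means that more compound is needed for the effect, a lower number that less compound is needed), the measured compounds stand as follows:

Compound 1 `O=C(NCc1ccc(CNS(=O)(=O)c2ccc(-c3ccc(F)cc3)cc2)cc1)c1ccc(F)cc1`: 100 nM
Compound 2 `O=C(NCc1ccc(CNS(=O)(=O)c2cccnc2)cc1)c1ccc(F)cc1`: 1000 nM
Compound 3 `Cc1ccc(S(=O)(=O)NCc2ccc(CNC(=O)c3ccc(F)cn3)cc2)cc1`: 1000 nM

Compound 2 sits, together with compound 3, at the highest number of the three, and the two are level with each other within the usual scatter. Compound 1 stands apart from them, with a number that is lower by a margin beyond the scatter, so compound 1 needs the least compound for the effect among those measured.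

The next compound, compound 4 `O=C(NCc1ccc(CNS(=O)(=O)c2ccc(Cl)cc2)cc1)c1ccc(F)cc1`, has not yet been measured in this assay. It differs from compound 2 in one place: 4-chlorophenyl in place of pyridin-3-yl on a sulfonyl sulfur. Nothing in the measured set shows exactly this change, so the direction can only be guessed from what the three numbers show. Because compound 1 gives 100 nM with a carbon-only aromatic ring on the same sulfonyl sulfur while compound 2 gives 1000 nM with a pyridin-3-yl ring there, compound 4 is expected to move toward a lower number, a step of moderate size, a 3.3-fold lower number from compound 2 to compound 4 (0.52 log units; beyond the scatter). For compound 4 the expected value in this assay is 300 nM, with a range from 100 nM to 1000 nM.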

Compound 4, effective concentration (reported as EC, without a stated level of effect): 100 nM
Estimate against measurement, compound 4: 3.0-fold (0.48 log units) above, within the range that was stated.
By their numbers in this assay, from the lowest: compounds 1 and 4 (each within the scatter of the next); then compounds 2 and 3 (each within the scatter of the next).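

Putting 4-chlorophenyl in place of pyridin-3-yl on the sulfonyl sulfur gives a 10-fold lower number from compound 2 to compound 4 (1.00 log units; beyond the scatter) in this assay, so this position clearly responds to the choice of ring when the rest of the molecule stays the same. Chloro in place of 4-fluorophenyl on an aromatic carbon gives no change at the digits printed from compound 1 to compound 4 (within the scatter) in this pair, so the extra 4-fluorophenyl ring of compound 1 is not needed to reach that level. Nothing shown here accounts for either result.

On these data alone, the step from compound 2 to compound 4 removes the ring nitrogen and adds the chloro together, so their separate shares remain open, and an unsubstituted phenyl ring on the sulfonyl sulfur would help to separate them. As far as these compounds go, how an amine or a carboxylic acid in place of the chloro would read is also open.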